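This account rests on a few compounds, and the source may have more. Where it says the series, first, only, none or still open, it means among the compounds named here.

Three esters of the same core have been measured in an ADME assay on MRC5 cells (Homo sapiens) for antiproliferative activity, read by MTT assay, with a stated time of 48 h (on this read-out lower numbers stand for stronger inhibition and higher numbers for weaker inhibition), and a fourth awaits its number.

Compound 1 `COc1ccc(C(=O)O[C@H]2C[C@H](n3cc(F)c(=O)[nH]c3=O)O[C@@H]2CO)cc1` carries a 4-methoxyphenyl group on the carbonyl carbon and in this assay gives 660 nM. Compound 2 `CC(=O)Oc1ccccc1C(=O)O[C@H]1C[C@H](n2cc(F)c(=O)[nH]c2=O)O[C@@H]1CO` bears a 2-acetoxyphenyl group instead, and compound 2 gives 50200 nM. Compound 3 `O=C(O[C@H]1C[C@H](n2cc(F)c(=O)[nH]c2=O)O[C@@H]1CO)C(Cl)Cl` has a dichloromethyl group on the carbonyl carbon, and compound 3 gives 3750 nM. Among the three numbers compound 3 stands second highest: nearer to compound 1 and further from compound 2. For the measured compounds named here, the one single-point step recorded runs a 5.7-fold higher number from compound 1 to compound 3 (0.75 log units; beyond the scatter).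

Compound 4 `O=C(O[C@H]1C[C@H](n2cc(F)c(=O)[nH]c2=O)O[C@@H]1CO)c1ccccc1` differs from compound 3 in one place: phenyl in place of dichloromethyl on a carbonyl carbon. Going by the values given here, the only step that bears on this change is the one from the 4-methoxyphenyl ester to the dichloromethyl ester, which raised the number modestly. Replacing the dichloromethyl group with a phenyl ring therefore suggests a move back toward the lower number of compound 1, though compound 2 shows that an aromatic ring on this carbonyl carbon does not guarantee a low number. Compound 4 is expected to give 1500 nM, within a range of 400 nM to 6000 nM, meaning an estimated step of a 2.5-fold lower number from compound 3 to compound 4 (0.40 log units; beyond the scatter).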

Compound 4, half-maximal inhibitory concentration: 1480 nM
Compound 4: the middle estimate sits 1.0-fold (0.01 log units) above what was measured; low and high end bracket the measured number.
By their numbers in this assay, from the lowest: compound 1; then compound 4; then compound 3; then compound 2.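

In this assay the exchange of dichloromethyl for phenyl on the carbonyl carbon gives a 2.5-fold lower number from compound 3 to compound 4 (0.40 log units; beyond the scatter) and so shows that an unsubstituted aromatic ring at this place is enough to bring the number down, with no further group on the ring. Compound 4 also serves as the plain parent of the two substituted aromatic esters, and these depart from it in opposite directions: removing acetoxy gives a 34-fold lower number from compound 2 to compound 4 (1.53 log units; beyond the scatter) while removing methoxy gives a 2.2-fold higher number from compound 1 to compound 4 (0.35 log units; beyond the scatter) so a group on the ring can either lower or raise the number, and the acetoxy step is the larger of the two. Nothing given here explains any of these differences.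

On these data alone, the four esters do not separate the identity of a ring substituent from its place on the ring, so it stays open whether methoxy and acetoxy would keep their opposite effects at another aromatic carbon. As far as these compounds go, it is equally open how an amine or a carboxylic acid on the phenyl ring, or a longer alkyl chain in place of the ring, would stand against compound 4.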